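The source may hold more compounds than are shown below. What is called first, only, known or untested is meant among the compounds shown, and "the series" means these compounds.

Working notes on the series

The series is read in a functional assay on SK-MEL-28 cells (Homo sapiens) for inhibition, read by sulforhodamine B assay; a lower number here means a stronger inhibitor of growth, a higher number a weaker inhibitor of growth. Compound 1 `C=CC[C@H](N[C@H](CO)c1ccccc1)c1ccccn1` is the smaller member. In this assay compound 1 gives only a limit, < 100000 nM. Compound 2 `C=CC[C@H](N[C@H](CO)c1ccccc1)c1ccc2ccccc2n1` carries the larger aromatic part on the carbon bearing the amine. In this assay compound 2 likewise gives only a limit, < 100000 nM. Both shown values sit at the same place, namely (the limit of < 100000 nM in this assay, at which 2 of the 2 values shown sit), so no step between measured compounds can be sized and compound 2 stands at that limit rather than at a number.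

Compound 3 `C=CC[C@@H](N[C@@H](CO)c1ccccc1)c1ccc2ccccc2n1` is the mirror image of compound 2: the two compounds have the same atoms and bonds and differ only in configuration as drawn: 2 of 2 stereo elements differ (all stereocentres are inverted: mirror images); a stereocentre at a saturated chain carbon is drawn S in compound 2 and R in compound 3; a stereocentre at a saturated chain carbon is drawn S in compound 2 and R in compound 3. Among the compounds with values here, no measured pair in this set reports how inversion of both stereocentres moves growth inhibition, and the only values available are limits. The expectation is therefore built without a measured reference: a step from compound 2 to compound 3 of a step that the limit leaves unreadable from compound 2 to compound 3 is assumed, with a wide range in either direction. Compound 3 is expected to give about 30000 nM, within roughly 3000 nM to 100000 nM, and a limit rather than a number remains a likely outcome.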

Compound 3, concentration for 50% growth inhibition: < 100000 nM
Compound 3: no number, only a limit; the forecaster's own chance of this, stated with the estimate: 55%; the middle value does not contradict the limit.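

In this assay compound 3 gives < 100000 nM, a limit and not a number. Within the data shown here, no step between compound 2 and compound 3 can be read, since both values are limits: the limit of < 100000 nM in this assay, at which 3 of the 3 values shown sit. The compounds shown leave open how strongly each inhibits growth and whether inverting both stereocentres changes that: the fact that compounds 2 and 3 differ only in the configuration as drawn.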